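A Halogen Swap on a Shared Core

This account rests on a few compounds, and the source may have more. Where it says the series, first, only, none or still open, it means among the compounds named here.

Compound 1 `COc1cc(-n2ncnc2-c2ccc(F)cc2)cc(OC)c1OC` carries a 4-fluorophenyl group, and in a functional assay on HeLa cells (Homo sapiens) for antiproliferative activity, read by MTT assay, with a stated time of 72 h (on this read-out lower numbers stand for stronger inhibition and higher numbers for weaker inhibition), compound 1 gives > 10000 nM, which is a limit of the assay. Compound 2 `COc1cc(-c2ncnn2-c2ccc(Cl)c(Cl)c2)cc(OC)c1OC`, bearing a 3,4-dichlorophenyl group, likewise reaches only a limit in this assay, where compound 2 gives > 10000 nM. Compound 3 `COc1cc(-c2ncnn2-c2ccc(F)cc2)cc(OC)c1OC`, with a 4-fluorophenyl group on an aromatic nitrogen, also sits at a limit in this assay, where compound 3 gives > 10000 nM. Among the measured compounds shown here, the single step between measured compounds, a step that the two limits leave unreadable from compound 2 to compound 3, therefore cannot be read for its size or direction. All that the measured compounds together show is the limit of > 10000 nM in this assay, at which 3 of the 3 values shown sit. Compound 1 thus stands at that limit, and the two further values stand there with it.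

Compound 4 `COc1cc(-n2ncnc2-c2cccc(Cl)c2)cc(OC)c1OC` differs from compound 1 by 3-chlorophenyl in place of 4-fluorophenyl on an aromatic carbon. For the measured compounds named here, no measured step bears directly on this change, and the one halogen step that was measured is unreadable, so no shift beyond the scatter can be expected in this assay in either direction. The change is expected to amount to a step that the limit leaves unreadable from compound 1 to compound 4. Compound 4 is therefore expected to give 20000 nM, within a range from 4000 nM to 100000 nM, most likely reported once more as a limit.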

Compound 4, half-maximal inhibitory concentration: > 10000 nM
Compound 4 gave a limit, no number; the forecaster's own chance of this, stated with the estimate: 75%; the middle value is on the limit's open side.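

In this assay compound 4 gives > 10000 nM, which is a limit and not a number. Compound 1 also stands at a limit, so no step can be read between compound 1 and compound 4, and the picture stays as it was: the limit of > 10000 nM in this assay, at which 4 of the 4 values shown sit. The compounds shown leave open what change to the shared core, if any, would give a readable number in this assay.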